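A few compounds are considered here, and "the series" means these few. Any claim that something is new, unique, unknown or untested is made for them only; others in the source may bear on it.

Compound 1 `CC1=C(C(=O)Nc2ccc(F)c(Cl)c2)C(c2cccc(O)c2)NC(=S)N1` is the weakest grower-inhibitor among the three measured compounds in a functional assay on PC-3 cells (Homo sapiens) for cytotoxicity, read by sulforhodamine B assay, with a stated time of 48 h (on this read-out lower numbers stand for stronger inhibition of growth and higher numbers for weaker inhibition of growth), where compound 1 gives 25100 nM. Compound 2 `CC1=C(C(=O)Nc2ccc(F)c(Cl)c2)C(c2ccccc2Cl)NC(=S)N1` gives 20400 nM, a step of a 1.2-fold lower number from compound 1 to compound 2 (0.09 log units; within the scatter). Compound 3 `CC1=C(C(=O)Nc2ccc(Cl)c(Cl)c2)C(c2cccc(O)c2)NC(=S)N1` gives 14100 nM, a step of a 1.8-fold lower number from compound 1 to compound 3 (0.25 log units; within the scatter). Compound 4 `CC1=C(C(=O)Nc2ccc(F)c(Cl)c2)C(c2cccc(Oc3ccccc3)c2)NC(=S)N1` differs from compound 1 by phenyl in place of hydrogen on an oxygen on an aromatic ring. Going by the values given here, no measured step alters this oxygen; the two known steps change other parts of compound 1 and both stay within the scatter, so they offer only indirect guidance. The step from compound 1 to compound 4 is therefore expected to be a 1.3-fold lower number from compound 1 to compound 4 (0.10 log units; within the scatter), with nothing clearly beyond the scatter. Compound 4 is estimated at 20000 nM, in the range 6000 nM to 60000 nM.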

Compound 4, concentration for 50% growth inhibition: 12000 nM
For compound 4 the middle estimate is 1.7-fold (0.22 log units) above the measured one, within the range that was stated.
By their numbers in this assay, from the lowest: compounds 4, 3, 2 and 1 (each within the scatter of the next, the first and the last beyond it).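

Going from hydroxy to phenoxy gives a 2.1-fold lower number from compound 1 to compound 4 (0.32 log units; beyond the scatter) in this assay and this is the only step so far that lies beyond the scatter, though it is modest. It shows that this oxygen can carry a whole phenyl ring without any loss of growth inhibition in these cells. No measurement shown here explains this step.

On these data alone, it remains open whether a small methyl on this oxygen would give a similar number, or whether the ring itself is needed. A longer chain or an amine at this place is equally untested in the compounds shown.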